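The source may report more compounds than this note shows. Statements on the series, on what has been measured and on what is new or still open speak of the compounds shown alone.

Measured compounds:
Compound 1 `COc1cc2c(Oc3ccc(NC(=O)/C=C/S(=O)(=O)c4ccccc4F)cc3F)ccnc2cc1OCCCN1CCN(C)CC1` — in a functional assay on A549 cells (Homo sapiens) for cytotoxicity, read by MTT assay, with a stated time of 72 h (on this read-out higher numbers stand for weaker inhibition and lower numbers for stronger inhibition), compound 1 gives 150 nM.
Compound 2 `COc1cc2c(Oc3ccc(NC(=O)/C=C/S(=O)(=O)c4ccc(C)cc4)cc3F)ccnc2cc1OCCCN1CCN(C)CC1` — in this assay compound 2 gives 1510 nM.

Among the compounds with values here, compound 1 gives the lowest of the two numbers so far; its nearest neighbour is compound 2, and the step of a 10-fold higher number from compound 1 to compound 2 (1.00 log units; beyond the scatter) is the only measured step in the set. That step exchanges the aryl group on the sulfonyl sulfur and leaves the rest of the shared core untouched.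

Compound 3 `COc1cc2c(Oc3ccc(NC(=O)/C=C/S(=O)(=O)c4ccccc4F)cc3F)ccnc2cc1OCCCN1CCC(C)CC1` differs from compound 1 at the other end of the molecule: 4-methylpiperidin-1-yl in place of 4-methylpiperazin-1-yl on a saturated chain carbon, three bonds along the chain from an oxygen on an aromatic ring. Within the data shown here, the one measured step, a 10-fold higher number from compound 1 to compound 2 (1.00 log units; beyond the scatter), concerns a different part of the structure and therefore does not bear on this change; no measured pair speaks to the terminal ring on the propyl chain. With no evidence for a shift in either direction, the expectation for this assay is a step of no more than the usual scatter, a 1.5-fold higher number from compound 1 to compound 3 (0.17 log units; within the scatter), with a slight allowance for a weaker number given that the ring now carries one hetero atom instead of two. Compound 3 is accordingly estimated at 220 nM, within a range from 70 nM to 700 nM.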

Compound 3, half-maximal inhibitory concentration: 410 nM
Beside the measured number, compound 3's estimate is 1.9-fold (0.27 log units) below it; the measured number falls inside the stated range.
By their numbers in this assay, from the lowest: compound 1; then compound 3; then compound 2.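

The terminal ring on the propyl chain proves not to be a silent part of the molecule: in this assay the change to 4-methylpiperidin-1-yl, which keeps the heavy-atom count and leaves one hetero atom in the ring in place of two, gives a 2.7-fold higher number from compound 1 to compound 3 (0.44 log units; beyond the scatter). Compound 1 keeps the lowest number of the three, and a change at either end of the molecule has now raised the number from it, the one on the sulfonyl sulfur being a 10-fold higher number from compound 1 to compound 2 (1.00 log units; beyond the scatter). Nothing measured here accounts for the step at the terminal ring, which therefore stands as an observation without an explanation.

The compounds shown leave open how a morpholine ring, a dimethylamino group or an unsubstituted piperazine at the end of the propyl chain would compare with compound 1, and whether an ethyl or butyl chain in place of the propyl chain would change the number. As far as these compounds go, the 4-methylpiperidin-1-yl group also appears here only with the 2-fluorophenyl group on the sulfonyl sulfur, so its effect alongside 4-methylphenyl remains unknown.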